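The source may report more compounds than this note shows. Statements on the series, on what has been measured and on what is new or still open speak of the compounds shown alone.

Measured compounds, all in a functional assay on CHO cells for antagonist activity at transient receptor potential cation channel subfamily V member 1 (Rattus norvegicus), read by calcium flux; a lower number here means a stronger inhibitor, a higher number a weaker inhibitor:
compound 1 `FC(F)(F)c1cccc(-c2[nH]c(N3CCN(c4ncccc4C(F)(F)F)CC3)nc2-c2ccccc2)c1`, 1240 nM
compound 2 `Fc1cc(F)cc(-c2nc(N3CCN(c4ncccc4C(F)(F)F)CC3)[nH]c2-c2ccc(C(F)(F)F)cc2)c1`, 35 nM
compound 3 `OCc1cnc(N2CCN(c3nc(-c4ccccc4)c(-c4ccc(C(F)(F)F)cc4)[nH]3)CC2)c(Cl)c1`, 90 nM

Compound 2 holds the lowest number of the three in this assay; compound 3 sits closest to it, a gap beyond the scatter, and compound 1 lies furthest away. Compound 4 `COC(=O)c1nc(N2CCN(c3ncccc3C(F)(F)F)CC2)[nH]c1-c1ccc(C(F)(F)F)cc1` is yet to be measured in this assay. It is obtained from compound 2 by methoxycarbonyl in place of 3,5-difluorophenyl on an aromatic carbon. Among the measured compounds shown here, no measured compound carries a non-ring group at that position, so the step has no direct precedent. A step upward, beyond the scatter, is expected, as a 17-fold higher number from compound 2 to compound 4 (1.23 log units; beyond the scatter). Compound 4 is estimated at 600 nM, with a range of 150 nM to 3000 nM.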

Compound 4, half-maximal inhibitory concentration: 1170 nM
Compound 4: middle estimate off by 2.0-fold (0.29 log units), on the low side, within the range that was stated.
By their numbers in this assay, from the lowest: compound 2; then compound 3; then compounds 4 and 1 (each within the scatter of the next).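

In this assay, among the compounds shown here, methoxycarbonyl in place of 3,5-difluorophenyl on this aromatic carbon gives a 33-fold higher number from compound 2 to compound 4 (1.52 log units; beyond the scatter), the only reading so far of a non-ring group at this position. The position is therefore sensitive to this change, which is large and beyond the scatter. No measurement at hand accounts for the step.

This single pair cannot separate losing the ring from introducing the ester. A carboxylic acid, a primary amide or a methyl group on this carbon could help to tell these apart.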